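The source may hold more compounds than are shown below. What is called first, only, known or untested is meant among the compounds shown, and "the series" means these compounds.

Of the compounds shown here, two built on the same core have been measured so far. Compound 1 `O=C1O[C@H]([C@@H](O)Cn2cc(-c3cc(C(F)(F)F)cc(C(F)(F)F)c3)nn2)C(OCc2ccccc2)=C1OCc1ccccc1` carries a bis(trifluoromethyl)phenyl group on its triazole ring; in a functional assay on HCT-116 cells (Homo sapiens) for antiproliferative activity, read by MTT assay, with a stated time of 72 h (on this read-out higher numbers stand for weaker inhibition and lower numbers for stronger inhibition), compound 1 gives 57200 nM. Compound 2 `CCCCc1cn(C[C@H](O)[C@H]2OC(=O)C(OCc3ccccc3)=C2OCc2ccccc2)nn1` carries a butyl chain at the same position instead, and in this assay compound 2 gives 10400 nM. Of the two numbers, that of compound 2 is the lower one, and the gap to compound 1 is beyond the usual scatter of such measurements, so compound 2 is the stronger inhibitor of cell growth among these two.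

Compound 3 `Cc1ccc(S(=O)(=O)NCc2cn(C[C@H](O)[C@H]3OC(=O)C(OCc4ccccc4)=C3OCc3ccccc3)nn2)cc1` is the next compound to be tested. It differs from compound 2 by ((4-methylphenyl)sulfonyl)amino in place of propyl on a saturated chain carbon bound to an aromatic carbon. Among the measured compounds shown here, no measured pair shows this exact exchange, so there is no step on which to lean. The change is sizeable, and the two measured compounds already show that the group on the triazole can move the number a good deal. The step from compound 2 to compound 3 is expected to be a 1.4-fold higher number from compound 2 to compound 3 (0.16 log units; within the scatter), a modest loss that may still sit within the scatter. Compound 3 is estimated at 15000 nM, with a range from 3500 nM to 60000 nM.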

Compound 3, half-maximal inhibitory concentration: 13100 nM
The estimate for compound 3 lay 1.1-fold (0.06 log units) above the measured number; measured number inside the range.
By their numbers in this assay, from the lowest: compounds 2 and 3 (each within the scatter of the next); then compound 1.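

In this assay, putting ((4-methylphenyl)sulfonyl)amino in place of propyl on a saturated chain carbon bound to an aromatic carbon gives a 1.3-fold higher number from compound 2 to compound 3 (0.10 log units; within the scatter) and so leaves the two compounds indistinguishable, even though a group of 11 heavy atoms with an aromatic ring, a hydrogen-bond donor and hydrogen-bond acceptors replaces one of 3 carbon atoms. This position therefore tolerates a much larger group with no change that stands clear of the scatter, and an aromatic ring in this part of the molecule is not enough on its own to give a number as high as that of compound 1 at 57200 nM in this assay. Nothing available here explains why the number holds steady across this exchange.

The compounds shown do not reveal whether the sulfonyl group, the amino hydrogen or the methylphenyl ring contributes anything separately, since these parts enter together. Nor do they show how a primary amine, a carboxylic acid or an alkyl chain longer than butyl would behave at this position.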